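Removing a Methyl from an Aryl Ether Series

The source may report more compounds than this note shows. Statements on the series, on what has been measured and on what is new or still open speak of the compounds shown alone.

Of the compounds shown here, three built on one shared core have been tested in an ADME assay on MT4 cells (Homo sapiens) for cytotoxicity, read by MTT assay, with a stated time of 5 days; on this read-out higher numbers stand for lower toxicity in this test and lower numbers for higher toxicity in this test. Compound 1 `N#Cc1ccc(Nc2nccc(NCc3ccccn3)n2)cc1` gives 8500 nM. Compound 2 `Cc1ccccc1COc1ccnc(Nc2ccc(C#N)cc2)n1` gives 12000 nM, and compound 3 `COc1cc(COc2ccnc(Nc3ccc(C#N)cc3)n2)cc(OC)c1` gives 44200 nM. Among these three numbers compound 2 holds the second highest. Its value lies close to that of compound 1, a gap that falls within the usual scatter of such measurements, so no order can be read between those two. Compound 3 sits further away, with a higher number that lies beyond the scatter.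

Compound 4 `N#Cc1ccc(Nc2nccc(OCc3ccccc3)n2)cc1` has not yet been tested. It differs from compound 2 in a single place: hydrogen in place of methyl on an aromatic carbon. Among the measured compounds shown here, no measured pair in this set shows what such a change does here, and so small a change gives no ground for expecting a move in either direction. The expected step, a 1.1-fold lower number from compound 2 to compound 4 (0.04 log units; within the scatter), is therefore judged to stay within the scatter. Compound 4 is estimated at 11000 nM in this assay, with a likely range from 4500 nM to 28000 nM.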

Compound 4, half-maximal cytotoxic concentration: 13000 nM
Compound 4: the middle estimate sits 1.2-fold (0.07 log units) below what was measured, within the range that was stated.
By their numbers in this assay, from the lowest: compounds 1, 2 and 4 (each within the scatter of the next); then compound 3.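

In this assay, among the compounds shown here, hydrogen in place of methyl on an aromatic carbon, ortho to a large group, gives a 1.1-fold higher number from compound 2 to compound 4 (0.03 log units; within the scatter), the first reading in this set of a change made in one place alone. At this position, then, the 2-methylbenzyl and benzyl groups cannot be told apart in this test of toxicity to the cells, as the step is no larger than the differences seen between repeated measurements. No measurement shown here offers an explanation for this result.

This single pair speaks only for methyl and hydrogen at this one place, not for the ring as a whole. As far as these compounds go, whether an amine, a carboxylic acid or a longer chain such as propyl on the same ring carbon would also leave the number within the scatter remains open.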